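Replacing methoxy with amino on a carbonyl carbon

This account rests on a few compounds, and the source may have more. Where it says the series, first, only, none or still open, it means among the compounds named here.

For the measured compounds named here, in a physicochemical assay for solubility, with a stated time of 4 h, at pH 7.4 (on this read-out higher numbers stand for higher solubility and lower numbers for lower solubility), compound 1 (`Cc1cc(CCC#N)cc(C)c1Oc1cc(Nc2ccc(C#N)cc2)c(N)cc1CO`) gives 18.8 ug/mL while compound 2 (`COC(=O)c1cc(N)c(Nc2ccc(C#N)cc2)cc1Oc1c(C)cc(CCC#N)cc1C`) gives 1.21 ug/mL and so holds the lower of the only two numbers so far. Going by the values given here, the single measured step is a 16-fold lower number from compound 1 to compound 2 (1.19 log units; beyond the scatter) and it is large, beyond the scatter, with methoxycarbonyl in place of hydroxymethyl on an aromatic carbon. Compound 3 (`Cc1cc(CCC#N)cc(C)c1Oc1cc(Nc2ccc(C#N)cc2)c(N)cc1C(N)=O`) keeps the shared core and has amino in place of methoxy on a carbonyl carbon which turns methoxycarbonyl into carbamoyl. Among the compounds with values here, no measured step shows this exact swap, so the earlier step is only a loose guide. With just a 16-fold lower number from compound 1 to compound 2 (1.19 log units; beyond the scatter) to go on, a rise that recovers part of that drop is expected. The expected move is a 4.1-fold higher number from compound 2 to compound 3 (0.62 log units; beyond the scatter) in this assay as a moderate estimate. Compound 3 is estimated at 5 ug/mL with an expected range from 1.5 ug/mL to 18 ug/mL across repeat measurements.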

Compound 3, solubility: 0.06 ug/mL
Estimate against measurement, compound 3: 83-fold (1.92 log units) above; the whole stated range lies above it.
By their numbers in this assay, from the lowest: compound 3; then compound 2; then compound 1.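

For the compounds shown here, on the shared core, the carbonyl carbon is not a place where only the step from hydroxymethyl matters: in this assay, amino in place of methoxy gives a 20-fold lower number from compound 2 to compound 3 (1.30 log units; beyond the scatter) while the carbonyl itself stays. Carbamoyl in place of hydroxymethyl gives a 310-fold lower number from compound 1 to compound 3 (2.50 log units; beyond the scatter) and so goes further than methoxycarbonyl did, which puts the three groups in a clear order at this place, with hydroxymethyl highest, methoxycarbonyl next and carbamoyl lowest. No supporting measurement here says why amino, which brings a hydrogen-bond donor, lowers the number.

From the compounds shown here alone, whether a carboxylic acid or an N-methyl amide on this carbonyl carbon would land nearer compound 1 or compound 3 remains open. So does whether this order of groups would hold on a different core.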